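Methoxy for methylpyrazolyl on the fused aromatic ring

A few compounds are considered here, and "the series" means these few. Any claim that something is new, unique, unknown or untested is made for them only; others in the source may bear on it.

In a functional assay on CHO cells for agonist activity at Alpha-1A adrenergic receptor (Homo sapiens), read by FLIPR and calcium flux (on this read-out lower numbers stand for an effect already at smaller amounts and higher numbers for an effect only at larger amounts of compound), compound 1 `c1ccc(-c2cccc3c2CCC3c2ncc[nH]2)nc1` gives 1150 nM. Compound 2 `COc1c(C)ccc2c1CCC2c1ncc[nH]1`, which carries a methoxy group and a methyl group in place of an aryl ring, gives 167 nM in this assay. Among the measured compounds shown here, for compound 3 `Cn1ccc(-c2cccc3c2CCC3c2ncc[nH]2)n1` this assay reports only a limit, > 1300 nM, so compound 3 stands at the upper edge of the series with no number of its own; the sole measured step that touches it, an at least 1.1-fold higher number from compound 1 to compound 3 (0.05 log units; that floor lies within the scatter), says only that its value is no smaller than that of compound 1, and the limit of > 1300 nM in this assay, at which 1 of the 3 values shown sits, marks where it sits.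

Compound 4 `COc1cccc2c1CCC2c1ncc[nH]1` is not yet measured. The change is methoxy in place of 1-methyl-1H-pyrazol-3-yl on an aromatic carbon. For the measured compounds named here, no measured step covers a move from an aryl ring to methoxy, so the expectation rests on the values alone: the pyridyl and methylpyrazolyl compounds both sit near or at the limit, while the methoxy-bearing compound 2 sits well lower. For compound 4 a step of an at least 4.3-fold lower number from compound 3 to compound 4 (0.63 log units; beyond the scatter) in this assay is therefore expected, toward smaller amounts, with the value estimated at 300 nM and a range from 100 nM to 1000 nM.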

Compound 4, half-maximal effective concentration: 32 nM
Compound 4: the middle estimate sits 9.4-fold (0.97 log units) above what was measured, and the stated range ends above it.
By their numbers in this assay, from the lowest: compound 4; then compound 2; then compound 1. At a limit, above all of these: compound 3.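

With methoxy on this aromatic carbon of the shared core, this assay shows a 36-fold lower number from compound 1 to compound 4 (1.56 log units; beyond the scatter) and an at least 40-fold lower number from compound 3 to compound 4 (1.60 log units; beyond the scatter), so neither pyridin-2-yl nor 1-methyl-1H-pyrazol-3-yl is needed for an effect at small amounts of compound. The second of these steps rests on a limit for compound 3, not on a number: the limit of > 1300 nM in this assay, at which 1 of the 4 values shown sits. The earlier methoxy compound also carried a methyl group; a 5.2-fold lower number from compound 2 to compound 4 (0.72 log units; beyond the scatter) now separates the two, with hydrogen in place of that methyl on an aromatic carbon giving the lower number.

As far as these compounds go, it stays open whether a hydroxyl group, an ethoxy group or a chlorine atom on this carbon would hold the value of the methoxy group. From the compounds shown here alone, the effect of changes elsewhere on the core also remains open.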